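This account rests on a few compounds, and the source may have more. Where it says the series, first, only, none or still open, it means among the compounds named here.

Compound 1 `CC(C)COc1ccc2oc(/C=C/[S+](C)[O-])cc(=O)c2c1`: 1100 nM
Compound 2 `CCCC(=O)Oc1ccc2oc(/C=C/[S+](C)[O-])cc(=O)c2c1`: 2200 nM
Compound 3 `Cc1ccc2oc(/C=C/[S+](C)[O-])cc(=O)c2c1`: 1700 nM

All three values come from a functional assay on A549 cells (Homo sapiens) for cytotoxicity, with a stated time of 48 h; on this read-out lower numbers stand for stronger inhibition and higher numbers for weaker inhibition. Compound 3 stands within the scatter of the other two: a 1.5-fold higher number from compound 1 to compound 3 (0.19 log units; within the scatter), and a 1.3-fold lower number from compound 2 to compound 3 (0.11 log units; within the scatter). Compound 4 `C[S+]([O-])/C=C/c1cc(=O)c2cc(F)ccc2o1` differs from compound 3 by fluoro in place of methyl on an aromatic carbon. Within the data shown here, no measured step involves fluoro, so the evidence is indirect. Exchanging the group on this aromatic carbon has so far given only small steps: a 1.5-fold higher number from compound 1 to compound 3 (0.19 log units; within the scatter), a 1.3-fold lower number from compound 2 to compound 3 (0.11 log units; within the scatter), and a 2.0-fold higher number from compound 1 to compound 2 (0.30 log units; within the scatter). No step beyond the scatter is therefore expected in this assay. The expected step is no change at the digits printed from compound 3 to compound 4 (within the scatter). For compound 4 the estimate is 1700 nM, with an expected range of 800 nM to 3600 nM.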

Compound 4, half-maximal inhibitory concentration: 2100 nM
Compound 4: the middle estimate sits 1.2-fold (0.09 log units) below what was measured; low and high end bracket the measured number.
By their numbers in this assay, from the lowest: compounds 1, 3, 4 and 2 (each within the scatter of the next).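

In this assay, among these compounds, fluoro is the first single-atom group on this aromatic carbon, and it adds no step beyond the scatter against methyl (a 1.2-fold higher number from compound 3 to compound 4 (0.09 log units; within the scatter)), against (propylcarbonyl)oxy (a 1.0-fold lower number from compound 2 to compound 4 (0.02 log units; within the scatter)) or against isobutoxy (a 1.9-fold higher number from compound 1 to compound 4 (0.28 log units; within the scatter)). The four compounds thus carry a halogen, a carbon-linked group and two oxygen-linked groups at this place, all within the scatter of their neighbours in the series. Nothing at hand accounts for this flat picture.
As far as these compounds go, whether an amine or a carboxylic acid on this aromatic carbon would give a step beyond the scatter remains open. So does the effect of changing the methyl sulfoxide-bearing side chain of the shared core.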